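Pyridin-3-yl in place of 4-chlorophenyl in compound 4

This account rests on a few compounds, and the source may have more. Where it says the series, first, only, none or still open, it means among the compounds named here.

Measured in a functional assay on HCT-15 cells (Homo sapiens) for cytotoxicity, read by ELISA, with a stated time of 4 days; a higher number here means a weaker inhibitor, a lower number a stronger inhibitor:
- Compound 1 `Cc1ccsc1-c1cc(-c2ccc(Cl)o2)cc(-c2ccco2)n1`: 26300 nM
- Compound 2 `Cc1ccsc1-c1cc(-c2ccc(Cl)o2)cc(-c2cccc(Cl)c2)n1`: 26400 nM
- Compound 3 `Cc1ccsc1-c1cc(-c2ccc(Cl)o2)cc(-c2ccc(Cl)cc2)n1`: 30300 nM

The three values sit close together, and compound 3, at 30300 nM, is not separated from the other two beyond the scatter. The next compound to be measured is compound 4 `Cc1ccsc1-c1cc(-c2ccc(Cl)o2)cc(-c2cccnc2)n1`, which carries pyridin-3-yl in place of 4-chlorophenyl on an aromatic carbon.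

Among the compounds with values here, three measured steps bear on this change, all made on that same aromatic carbon. They are a 1.0-fold higher number from compound 1 to compound 2 (0.00 log units; within the scatter), a 1.2-fold higher number from compound 1 to compound 3 (0.06 log units; within the scatter) and a 1.1-fold higher number from compound 2 to compound 3 (0.06 log units; within the scatter). Each is small, and none leaves the scatter. Within the data shown here, no measured compound carries pyridin-3-yl, so these steps offer only indirect guidance. On their evidence, no step beyond the scatter is expected in this assay, in either direction. The expected step is a 1.1-fold lower number from compound 3 to compound 4 (0.03 log units; within the scatter). Compound 4 is estimated at 28000 nM, with an expected range of 13000 nM to 55000 nM.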

Compound 4, half-maximal inhibitory concentration: > 50000 nM
Compound 4: a limit, no number; the forecaster's own chance of this, stated with the estimate: 10%; at least 1.7-fold (0.25 log units) between middle value and limit.
By their numbers in this assay, from the lowest: compounds 1, 2 and 3 (each within the scatter of the next). At a limit, above all of these: compound 4.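

The value of compound 4 in this assay is a limit of the assay and not a number, so this change can be read only as a floor: the limit of > 50000 nM in this assay, at which 1 of the 4 values shown sits.

Pyridin-3-yl on this aromatic carbon gives an at least 1.6-fold higher number from compound 3 to compound 4 (0.21 log units; that floor lies within the scatter), an at least 1.8-fold higher number from compound 2 to compound 4 (0.27 log units; that floor lies within the scatter) and an at least 1.9-fold higher number from compound 1 to compound 4 (0.27 log units; that floor lies within the scatter). Each floor lies within the scatter, so the result does not establish a real loss, but unlike the three earlier groups, pyridin-3-yl no longer gives a value that can be placed beside theirs.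

On these data alone, how far compound 4 lies past its limit stays open, as does how an amine or a carboxylic acid on this carbon would read in this assay. As far as these compounds go, all four compounds keep the 3-methylthiophen-2-yl and 5-chlorofuran-2-yl groups, so the effect of changing either one also stays open.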